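A few compounds are considered here, and "the series" means these few. Any claim that something is new, unique, unknown or untested is made for them only; others in the source may bear on it.

Measured so far in a functional assay on HeLa cells (Homo sapiens) for cytotoxicity, read by WST assay, with a stated time of 48 h; on this read-out higher numbers stand for weaker inhibition and lower numbers for stronger inhibition:
- compound 1, `CCCCC[C@H](C(C)C)C(c1ccc(O)c(OC)c1)c1ccc(O)c(OC)c1`: 9200 nM
- compound 2, `COC[C@H](C(C)C)C(c1ccc(O)c(OC)c1)c1ccc(O)c(OC)c1`: 76000 nM
- compound 3, `COc1cc(C(c2ccc(O)c(OC)c2)[C@H](C)[C@@H](C)CF)ccc1O`: 34000 nM

Compound 3 stands second highest of the three numbers; its nearest neighbour is compound 2, with a 2.2-fold lower number from compound 2 to compound 3 (0.35 log units; beyond the scatter), and its furthest is compound 1, with a 3.7-fold higher number from compound 1 to compound 3 (0.57 log units; beyond the scatter).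

The next compound, compound 4, is `COC[C@@H](C)[C@H](C)C(c1ccc(O)c(OC)c1)c1ccc(O)c(OC)c1`. The change from compound 3 is 2-(methoxymethyl)-1-methylpropyl in place of 2-(fluoromethyl)-1-methylpropyl on a saturated chain carbon bound to two aromatic carbons.

Two of the measured steps bear on this change. The first is an 8.3-fold higher number from compound 1 to compound 2 (0.92 log units; beyond the scatter), where a methoxy took the place of a butyl on a saturated chain carbon: a shift in the direction of higher numbers. The second is a 2.2-fold lower number from compound 2 to compound 3 (0.35 log units; beyond the scatter), where a chain carrying a fluoromethyl took the place of a chain carrying a methoxymethyl, giving a lower number. Compound 4 reverses that second kind of exchange, a methoxymethyl entering where a fluoromethyl leaves, so a modest step towards a higher number is expected, about the size of the step between compound 2 and compound 3, and beyond the scatter is possible but not certain.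

Compound 4 is therefore expected to give about 65000 nM in this assay, within the range 28000 nM to 150000 nM. This estimate corresponds to a step of a 1.9-fold higher number from compound 3 to compound 4 (0.28 log units; within the scatter), expected in the direction of weaker inhibition.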

Compound 4, half-maximal inhibitory concentration: 58000 nM
Compound 4: middle estimate off by 1.1-fold (0.05 log units), on the high side; low and high end bracket the measured number.
By their numbers in this assay, from the lowest: compound 1; then compounds 3, 4 and 2 (each within the scatter of the next, the first and the last beyond it).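

In this assay, 2-(methoxymethyl)-1-methylpropyl in place of 2-(fluoromethyl)-1-methylpropyl on a saturated chain carbon bound to two aromatic carbons gives a 1.7-fold higher number from compound 3 to compound 4 (0.23 log units; within the scatter), so this position does not separate the two chains, even though the entering chain has one hydrogen-bond acceptor and the leaving chain has none. Compound 4 also allows a comparison of two chains that both carry a methoxymethyl: 2-(methoxymethyl)-1-methylpropyl in place of 1-(methoxymethyl)-2-methylpropyl gives a 1.3-fold lower number from compound 2 to compound 4 (0.12 log units; within the scatter), so these two arrangements cannot be told apart either. The clear separation remains the one from the 1-isopropylhexyl chain, with a 6.3-fold higher number from compound 1 to compound 4 (0.80 log units; beyond the scatter), which places compound 4 with the other short chains on the weaker side of compound 1.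

No measurement on hand accounts for any of these steps. Open questions are whether an amine or a carboxylic acid on this chain would stay level with compounds 2, 3 and 4, and whether a longer chain carrying a methoxy would come closer to compound 1.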